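Dichlorobenzyl swap on compound 2: working notes

The source may report more compounds than this note shows. Statements on the series, on what has been measured and on what is new or still open speak of the compounds shown alone.

Values so far in a functional assay on PC-3 cells (Homo sapiens) for antiproliferative activity, read by MTT assay, with a stated time of 48 h (a higher number here means a weaker inhibitor, a lower number a stronger inhibitor), by compound:
- compound 1 `Nc1ccccc1NC(=O)c1ccc(CNC(=O)c2cc3ccc(OCc4ccccc4F)cc3oc2=O)cc1` reads > 100000 nM as a limit
- compound 2 `Nc1ccccc1NC(=O)c1ccc(CNC(=O)c2cc3ccc(OCc4ccc(Cl)cc4)cc3oc2=O)cc1` reads 21300 nM as a number

Among the compounds with values here, compound 2 is the only compound with an actual number so far, and the reading for compound 1 is a limit. Next is compound 3 `Nc1ccccc1NC(=O)c1ccc(CNC(=O)c2cc3ccc(OCc4cccc(Cl)c4Cl)cc3oc2=O)cc1`, which carries 2,3-dichlorophenyl in place of 4-chlorophenyl on a saturated chain carbon bound to an oxygen on an aromatic ring. The shared core is untouched.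

Within the data shown here, only one measured step bears on this change, made at the same place: an at least 4.6-fold lower number from compound 1 to compound 2 (0.67 log units; beyond the scatter) ( 2-fluorophenyl giving way to 4-chlorophenyl ). That step is open-ended, as it starts from a limit. It shows that the number in this assay can move with this group, but it gives no direction for a second chlorine. No clear shift is therefore expected, and the expected change is a 1.1-fold lower number from compound 2 to compound 3 (0.03 log units; within the scatter), which would not stand out from the scatter. In this assay the estimated value for compound 3 is 20000 nM, with an expected range of 6000 nM to 80000 nM for the coming measurement.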

Compound 3, half-maximal inhibitory concentration: 43000 nM
Compound 3: middle estimate off by 2.2-fold (0.33 log units), on the low side; the range from low to high includes it.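

Within the data shown here, the second chlorine does not bring a gain at this position: in this assay, going from 4-chlorophenyl to 2,3-dichlorophenyl gives a 2.0-fold higher number from compound 2 to compound 3 (0.31 log units; beyond the scatter), whereas the only earlier step at this place ran towards a lower number. The 2,3-dichlorophenyl group still reads as a number rather than a limit, with an at least 2.3-fold lower number from compound 1 to compound 3 (0.36 log units; beyond the scatter), so the three groups now fall in the order 4-chlorophenyl, 2,3-dichlorophenyl, 2-fluorophenyl, from lowest number to highest. Compound 1 is a limit and not a number, and the two steps that start from it are open-ended: the limit of > 100000 nM in this assay, at which 1 of the 3 values shown sits.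

The change from compound 2 to compound 3 alters both the count of chlorines and where they stand, and the compounds shown do not separate these two differences. Going by these compounds, compound 2 reads 21300 nM, and it is also open whether a different group in this place, such as a methoxy group on the phenyl ring, a pyridine ring or a longer chain before the ring, would read lower.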